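Swapping the Amine Tail: Will Cytotoxicity Stay Undetected?

A few compounds are considered here, and "the series" means these few. Any claim that something is new, unique, unknown or untested is made for them only; others in the source may bear on it.

Three compounds share one core and differ only in the group attached to an aromatic carbon of it. Compound 1 is `Cc1ccc2c(NCc3ccc(NC(=O)C4CCN(Cc5ccccc5)CC4)cc3)nc(N3CCNC(CCO)C3)nc2c1`, compound 2 is `Cc1ccc2c(NCc3ccc(NC(=O)C4CCN(Cc5ccccc5)CC4)cc3)nc(N3CCCC3)nc2c1` and compound 3 is `Cc1ccc2c(NCc3ccc(NC(=O)C4CCN(Cc5ccccc5)CC4)cc3)nc(N(C)CCN(C)C)nc2c1`. In a functional assay on SV5A8 cells (Homo sapiens) for cytotoxicity (a higher number here means a weaker inhibitor, a lower number a stronger inhibitor), compound 1 gives > 8420 nM, which is a limit of the assay rather than a number. Compound 2 likewise gives > 7790 nM, again a limit. Compound 3 gives > 8830 nM, also a limit. For compound 3 this is the limit of > 8830 nM in this assay, at which 1 of the 3 values shown sits. So compound 3 stands at a limit, and the two other values shown are limits as well. As all three values are limits, the step that the two limits leave unreadable from compound 1 to compound 2, the step that the two limits leave unreadable from compound 1 to compound 3 and the step that the two limits leave unreadable from compound 2 to compound 3 cannot be read in size or direction. The unmeasured compound 4 is `CCN1CCN(c2nc(NCc3ccc(NC(=O)C4CCN(Cc5ccccc5)CC4)cc3)c3ccc(C)cc3n2)CC1`; its change from compound 3 is 4-ethylpiperazin-1-yl in place of (2-(dimethylamino)ethyl)(methyl)amino on an aromatic carbon. All three measured steps bear on it, each exchanging the group on that aromatic carbon, yet none gives a readable size, so no step beyond the scatter can be inferred in either direction. Compound 4 is therefore expected to sit at a limit as well, with an estimated value of 10000 nM in a range from 5000 nM to 30000 nM. The step that the limit leaves unreadable from compound 3 to compound 4 is expected to stay within the scatter.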

Compound 4, half-maximal inhibitory concentration: > 13000 nM
Compound 4: only a limit was reported (the forecaster's own chance of this, stated with the estimate: 85%); middle value at least 1.3-fold (0.11 log units) away from the limit.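

In this assay compound 4 gives > 13000 nM, which is a limit of the assay and not a number. Its steps from compound 1, compound 2 and compound 3 therefore cannot be read in size or direction. The compounds shown leave open whether any of these four groups on that aromatic carbon would give a measured value, and how far the four compounds truly differ.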